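Bromophenyl for chlorofluorophenyl on a thiourea-linked core

A few compounds are considered here, and "the series" means these few. Any claim that something is new, unique, unknown or untested is made for them only; others in the source may bear on it.

Compound 1 `COc1cc2ncnc(Nc3ccc(F)c(Br)c3)c2cc1OCCCCC(=O)Nc1ccc(S(N)(=O)=O)cc1`: 16000 nM
Compound 2 `COc1cc2ncnc(Nc3cccc(Cl)c3F)c2cc1OCCCCC(=O)Nc1ccc(S(N)(=O)=O)cc1`: 10500 nM
Compound 3 `NS(=O)(=O)c1ccc(NC(=S)Nc2ccc3ncnc(Nc4ccc(F)c(Cl)c4)c3c2)cc1`: > 40000 nM

In a functional assay on A549 cells (Homo sapiens) for antiproliferative activity, read by MTT assay, with a stated time of 72 h (a higher number here means a weaker inhibitor, a lower number a stronger inhibitor), compound 1 gives 16000 nM and compound 2 gives 10500 nM. For compound 3 the assay reports only a limit, > 40000 nM, so its true value is not known beyond that. Compound 4 `NS(=O)(=O)c1ccc(NC(=S)Nc2ccc3ncnc(Nc4cccc(Br)c4)c3c2)cc1` shares the thiourea-linked core of compound 3 and differs from it in one place: 3-bromophenyl in place of 3-chloro-4-fluorophenyl on a nitrogen on an aromatic ring. Among the compounds with values here, the only measured step that touches the same kind of change is the one between compounds 1 and 2, also an exchange of the halogen pattern on the same anilino group: a 1.5-fold lower number from compound 1 to compound 2 (0.18 log units; within the scatter). On that basis no shift beyond the scatter is expected in this assay, and since compound 3 already sits at the limit of > 40000 nM in this assay, at which 1 of the 3 values shown sits, compound 4 is expected to remain near that limit as well, with the step that the limit leaves unreadable from compound 3 to compound 4 expected. Compound 4 is therefore estimated at 45000 nM, in a range from 15000 nM to 120000 nM.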

Compound 4, half-maximal inhibitory concentration: 25000 nM
Estimate against measurement, compound 4: 1.8-fold (0.26 log units) above; the range from low to high includes it.
By their numbers in this assay, from the lowest: compounds 2, 1 and 4 (each within the scatter of the next, the first and the last beyond it). At a limit, above all of these: compound 3.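

Compound 4 gives the thiourea-linked core a readable number in this assay, which shows that the (3-bromophenyl)amino group at this position brings the core within the range of the assay, where the (3-chloro-4-fluorophenyl)amino group did not. Exchanging the 3-chloro-4-fluorophenyl for the 3-bromophenyl gives an at least 1.6-fold lower number from compound 3 to compound 4 (0.20 log units; that floor lies within the scatter), so this change can be read only as a floor, and that floor alone does not establish a real shift. Compound 3 stands at a limit: the limit of > 40000 nM in this assay, at which 1 of the 4 values shown sits.

The compounds shown do not separate the exchange of chlorine for bromine from the loss of the fluorine, as the two groups differ in both. On these data alone, how a 3-chlorophenyl or a plain phenyl would read on this core remains open.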